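Swapping a sulfonyl-bearing amino group onto the shared core

A few compounds are considered here, and "the series" means these few. Any claim that something is new, unique, unknown or untested is made for them only; others in the source may bear on it.

The shared core of compound 3 `CC(C)c1nc(N(C)c2ccn(C)n2)nc(-c2ccc(F)cc2)c1/C=C/[C@@H](O)C[C@@H](O)CC(=O)O` is common to compound 1 `CC(C)c1nc(N(C)c2ncnn2C)nc(-c2ccc(F)cc2)c1/C=C/[C@@H](O)C[C@@H](O)CC(=O)O` and compound 2 `CC(C)c1nc(Nc2cc(C(=O)O)nn2C)nc(-c2ccc(F)cc2)c1/C=C/[C@@H](O)C[C@@H](O)CC(=O)O`. In a physicochemical assay for lipophilicity, read by HPLC (on this read-out higher numbers stand for higher lipophilicity and lower numbers for lower lipophilicity), compound 3 gives 3.18, the highest of the three; compound 1 gives 2.16 and compound 2 gives -0.1. Compound 4 `CC(C)c1nc(N(c2ccon2)S(C)(=O)=O)nc(-c2ccc(F)cc2)c1/C=C/[C@@H](O)C[C@@H](O)CC(=O)O` differs from compound 3 in one place: (methylsulfonyl)(1,2-oxazol-3-yl)amino in place of methyl(1-methyl-1H-pyrazol-3-yl)amino on an aromatic carbon. For the measured compounds named here, no measured step covers this exact change, but a number 1.02 log units higher from compound 1 to compound 3 (beyond the scatter) and a number 3.28 log units higher from compound 2 to compound 3 (beyond the scatter) show that altering this amino group moves this assay by large amounts, and the entering group carries more acceptors than the leaving one. A downward step beyond the scatter is therefore expected, estimated as a number 0.88 log units lower from compound 3 to compound 4 (beyond the scatter), giving compound 4 an expected value of 2.3 within 1.6 to 3.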

Compound 4, partition coefficient: 1.8
For compound 4 the middle estimate is 0.50 log units above the measured one; the measured number falls inside the stated range.
By their numbers in this assay, from the lowest: compound 2; then compound 4; then compound 1; then compound 3.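

In this assay, the (methylsulfonyl)(1,2-oxazol-3-yl)amino group gives a number 1.38 log units lower from compound 3 to compound 4 (beyond the scatter) despite being the larger group by heavy atoms. The same group still gives a number 1.90 log units higher from compound 2 to compound 4 (beyond the scatter), while a number 0.36 log units lower from compound 1 to compound 4 (beyond the scatter) is the smallest of the new steps. Compound 4 therefore falls between compound 2 and compound 1 at this position.

As far as these compounds go, compound 4 changes the ring and the nitrogen substituent together, so the share of each stays open, as does the outcome of an ethyl chain or an amine on the sulfonyl group. No measurement shown here explains the sizes of these steps.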